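Sulfonamide notes: from compound 2 to compound 4

The source may report more compounds than this note shows. Statements on the series, on what has been measured and on what is new or still open speak of the compounds shown alone.

Values so far in a functional assay on HL-60 cells (Homo sapiens) for cytotoxicity, read by MTT assay (on this read-out lower numbers stand for stronger inhibition and higher numbers for weaker inhibition), are as follows.
- compound 1 `Cc1ccccc1S(=O)(=O)NC(C1=CC(=O)c2c(O)ccc(O)c2C1=O)C(C)C` gives 190 nM
- compound 2 `COc1ccc(S(=O)(=O)NC(C2=CC(=O)c3c(O)ccc(O)c3C2=O)C(C)C)cc1` gives "not determined" (no result reported)
- compound 3 `CC(C)C(NS(=O)(=O)c1ccc(F)cc1)C1=CC(=O)c2c(O)ccc(O)c2C1=O` gives "not determined" (no result reported)

Compound 2 has no single number and so holds no place on the scale. Compound 3 is in the same position. The only numeric reference in the series is compound 1 at 190 nM, and no ranking or trend can be drawn from one number.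

The next compound to be tested is compound 4 `CC(C)C(NS(=O)(=O)c1ccccc1Br)C1=CC(=O)c2c(O)ccc(O)c2C1=O`, which keeps the shared core. The change is 2-bromophenyl in place of 4-methoxyphenyl on a sulfonyl sulfur and it puts 2-bromophenyl in place of 4-methoxyphenyl on a sulfonyl sulfur. Going by the values given here, no measured step shows what a change at this place does, and the missing number for compound 2 leaves no starting point for this one. The expectation therefore rests on compound 1 at 190 nM alone, which is thin support. In this assay no shift from that value beyond the usual scatter is expected, in either direction. Compound 4 is estimated at 200 nM with 70 nM to 600 nM as the expected range.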

Compound 4, half-maximal inhibitory concentration: 340 nM
The estimate for compound 4 lay 1.7-fold (0.23 log units) below the measured number; measured number inside the range.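

Compound 4 gives the series its first readable step. In this assay, bromo in place of methyl on an aromatic carbon gives a 1.8-fold higher number from compound 1 to compound 4 (0.25 log units; within the scatter), so at this place on the sulfonyl sulfur the two compounds cannot be told apart, and both groups are compatible with activity in the nanomolar range. No available data explain this result.

The steps that would connect compound 4 to compound 2 or compound 3 cannot be read, as neither of those compounds has a single number, so the 4-methoxyphenyl group remains unplaced relative to 2-bromophenyl. The compounds shown also leave open whether an amine or a carboxylic acid in place of the bromo, or a longer chain such as propyl, would give a number clearly apart from compound 4, as the only step available here stays within the scatter and marks out no limit for this place.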